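Compound 3 to compound 4: 4-chlorophenyl to 4-nitrophenyl

The compounds below may be only part of what the source reports. "The series", "measured", "known", "first", "only" and "open" are said of these compounds alone.

In a functional assay on MCF7 cells (Homo sapiens) for cytotoxicity, read by MTT assay, with a stated time of 48 h (on this read-out higher numbers stand for weaker inhibition and lower numbers for stronger inhibition), compound 1 (`Cc1ccc(/C=C2/S/C(=N/c3ccccc3)N(Cc3ccncc3)C2=O)cc1`) gives 36900 nM while compound 2 (`O=C1/C(=C\c2ccc(O)cc2)S/C(=N/c2ccccc2)N1Cc1ccncc1`) gives 18900 nM and compound 3 (`O=C1/C(=C\c2ccc(Cl)cc2)S/C(=N/c2ccccc2)N1Cc1ccncc1`) gives 54900 nM in the same read-out. Compound 3 is separated from only one of the other two, as the steps show (a 1.5-fold higher number from compound 1 to compound 3 (0.17 log units; within the scatter) against a 2.9-fold higher number from compound 2 to compound 3 (0.46 log units; beyond the scatter)). The remaining step also stays inside the scatter (a 2.0-fold lower number from compound 1 to compound 2 (0.29 log units; within the scatter)).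

Compound 4 (`O=C1/C(=C\c2ccc([N+](=O)[O-])cc2)S/C(=N/c2ccccc2)N1Cc1ccncc1`) differs from compound 3 in one place, with nitro in place of chloro on an aromatic carbon. Going by the values given here, no measured compound carries nitro, so the measured steps serve only as a gauge of how far exchanges at this place have moved the number. The largest of them is modest (a 2.9-fold higher number from compound 2 to compound 3 (0.46 log units; beyond the scatter)) and no step beyond the scatter is expected in this assay for this exchange. The estimated step is small (a 1.4-fold lower number from compound 3 to compound 4 (0.16 log units; within the scatter)). Compound 4 is estimated at 38000 nM with an expected range of 16000 nM to 90000 nM in this read-out.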

Compound 4, half-maximal inhibitory concentration: 13000 nM
The estimate for compound 4 lay 2.9-fold (0.47 log units) above the measured number, and the stated range ends above it.
By their numbers in this assay, from the lowest: compounds 4, 2, 1 and 3 (each within the scatter of the next, the first and the last beyond it).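

Going by these compounds alone, at this aromatic carbon, para to a large group, the exchange of chloro for nitro gives the largest step so far (a 4.2-fold lower number from compound 3 to compound 4 (0.63 log units; beyond the scatter)), so this place can move the number further than the earlier exchanges showed. Nitro in place of methyl also passes the scatter (a 2.8-fold lower number from compound 1 to compound 4 (0.45 log units; beyond the scatter)), which neither earlier step from methyl did, whereas nitro in place of hydroxy stays inside it (a 1.5-fold lower number from compound 2 to compound 4 (0.16 log units; within the scatter)), leaving compound 2 and compound 4 without an order between them. Nothing at hand gives a cause for any of these steps.

As far as these compounds go, whether an amine or a carboxylic acid at this carbon would fall with nitro and hydroxy, or with methyl and chloro, stays open. Also open, from the compounds shown here alone, is whether the step from chloro to nitro would hold with a different group on the ring nitrogen of the shared core.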